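Cyclohexyl in place of cyclobutyl: working notes

A few compounds are considered here, and "the series" means these few. Any claim that something is new, unique, unknown or untested is made for them only; others in the source may bear on it.

Measured so far in a functional assay (Nicotiana tabacum); a higher number here means a weaker inhibitor, a lower number a stronger inhibitor:
- compound 1 `CCCNc1nc(SC)nc2ncccc12` gives 270 nM
- compound 2 `CSc1nc(NC2CCC2)c2cccnc2n1` gives 720 nM

Compound 2 holds the higher of the two numbers, at 720 nM on this short scale. The next compound, compound 3 `CSc1nc(NC2CCCCC2)c2cccnc2n1`, differs from it by one change: cyclohexyl in place of cyclobutyl on a nitrogen on an aromatic ring. Among the measured compounds shown here, one measured step bears on this, a 2.7-fold higher number from compound 1 to compound 2 (0.43 log units; beyond the scatter), which is modest and made at the same place. For the measured compounds named here, it is thin evidence, since no cyclohexyl compound has been measured. A further modest rise in the number in this assay is nevertheless expected, with the direction resting on that step alone. The expected move is a 1.4-fold higher number from compound 2 to compound 3 (0.14 log units; within the scatter) and could prove smaller. For compound 3 the estimate is 1000 nM with an expected range of 300 nM to 3500 nM for now.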

Compound 3, half-maximal inhibitory concentration: 5650 nM
Beside the measured number, compound 3's estimate is 5.7-fold (0.75 log units) below it; the whole stated range lies below it.
By their numbers in this assay, from the lowest: compound 1; then compound 2; then compound 3.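

At this position on the nitrogen, this assay separates the two carbon rings clearly: cyclohexyl in place of cyclobutyl gives a 7.8-fold higher number from compound 2 to compound 3 (0.89 log units; beyond the scatter) and so the six-membered ring is not interchangeable with the four-membered one. Against the open chain the move is wider still, with cyclohexyl in place of propyl giving a 21-fold higher number from compound 1 to compound 3 (1.32 log units; beyond the scatter) and compound 3 carrying the highest number of the three, so changing this one group spans a large range. Nothing available explains this response at the position.

The compounds shown leave open whether cyclopentyl would sit closer to cyclobutyl or to cyclohexyl, and whether the rise with ring size is smooth or abrupt. They also leave open whether a chain longer than propyl, or a hydroxyl on the cyclohexyl ring, would bring the number back toward that of compound 1.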